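Methoxy for methyl on the ester aryl ring

The source may hold more compounds than are shown below. What is called first, only, known or untested is meant among the compounds shown, and "the series" means these compounds.

Compound 1 `Cc1ccc(/C=C/C(=O)Oc2ccc(/C=C3\CCCCC3=O)cc2)cc1` and compound 2 `COc1ccc(/C=C/C(=O)Oc2ccc(/C=C3\CCCCC3=O)cc2)cc1` share one core; compound 3 `Cc1ccc(C(=O)Oc2ccc(/C=C3\CCCCC3=O)cc2)cc1` and compound 4 `COc1ccc(C(=O)Oc2ccc(/C=C3\CCCCC3=O)cc2)cc1` share another, and the difference between the two cores is not broken down here. In a functional assay on P388 cells (Mus musculus) (a higher number here means a weaker inhibitor, a lower number a stronger inhibitor), compound 1 reaches only the limit of > 50000 nM. Compound 2 gives 9030 nM in this assay. The change methoxy in place of methyl on an aromatic carbon thus made an at least 5.5-fold lower number from compound 1 to compound 2 (0.74 log units; beyond the scatter), which is only a lower bound because of the limit of > 50000 nM in this assay, at which 2 of the 3 values shown sit. Compound 3 in this assay likewise reaches only the limit of > 50000 nM. Compound 4 carries the same change, (methoxy in place of methyl on an aromatic carbon), on the core of compound 3. For compound 4 a step of an at least 2.5-fold lower number from compound 3 to compound 4 (0.39 log units; beyond the scatter) is expected. This rests on compound 1 and compound 2 through an at least 5.5-fold lower number from compound 1 to compound 2 (0.74 log units; beyond the scatter) alone; the two cores differ, and that is not accounted for. Compound 4 is estimated at 20000 nM, between 6000 nM and 50000 nM.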

Compound 4, half-maximal inhibitory concentration: > 50000 nM
Compound 4 gave a limit, no number (the forecaster's own chance of this, stated with the estimate: 35%); middle value at least 2.5-fold (0.39 log units) away from the limit.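

No step from compound 3 to compound 4 can be read, because both stop at the same limit: the limit of > 50000 nM in this assay, at which 3 of the 4 values shown sit.

The compounds shown leave open whether methoxy in place of methyl lowers the number on the core of compound 3 at all.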